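Methoxyphenyl pattern swap on the acrylic acid series

A few compounds are considered here, and "the series" means these few. Any claim that something is new, unique, unknown or untested is made for them only; others in the source may bear on it.

Compound 1 `COc1cccc(/C(=C\c2cn(C(C)=O)c3ccc(OCc4ccccc4)cc23)C(=O)O)c1` gives 1080 nM in a functional assay on DU-145 cells (Homo sapiens) for cytotoxicity, read by MTT assay, with a stated time of 72 h; on this read-out higher numbers stand for weaker inhibition and lower numbers for stronger inhibition. Compound 2 `COc1ccccc1/C(=C\c1cn(C(C)=O)c2ccc(OCc3ccccc3)cc12)C(=O)O` gives 1010 nM in this assay, and compound 3 `COc1ccc(OC)c(/C(=C\c2cn(C(C)=O)c3ccc(OCc4ccccc4)cc23)C(=O)O)c1` gives 830 nM. Compound 3 carries the lowest of the three numbers, but its gaps to compound 2 and to compound 1 both fall within the scatter, so the three compounds stand level. The next step leads to compound 4 `COc1ccc(/C(=C\c2cn(C(C)=O)c3ccc(OCc4ccccc4)cc23)C(=O)O)cc1OC` and consists of 3,4-dimethoxyphenyl in place of 2,5-dimethoxyphenyl on a double-bonded chain carbon bound to a carbonyl carbon and a double-bonded chain carbon. Within the data shown here, the one measured step that reshuffles the substitution pattern of the aryl group, a 1.1-fold lower number from compound 1 to compound 2 (0.03 log units; within the scatter), stayed within the scatter; the two steps that add a methoxy group, a 1.3-fold lower number from compound 1 to compound 3 (0.11 log units; within the scatter) and a 1.2-fold lower number from compound 2 to compound 3 (0.09 log units; within the scatter), stayed within the scatter as well. Moving both methoxy groups to new positions is therefore expected to give a 1.1-fold higher number from compound 3 to compound 4 (0.04 log units; within the scatter), nothing beyond the scatter. Compound 4 is estimated at 900 nM in this assay. For compound 4 the expected range runs from 400 nM to 2000 nM.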

Compound 4, half-maximal inhibitory concentration: 1050 nM
For compound 4 the middle estimate is 1.2-fold (0.07 log units) below the measured one; measured number inside the range.
By their numbers in this assay, from the lowest: compounds 3, 2, 4 and 1 (each within the scatter of the next).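

At the place on a double-bonded chain carbon bound to a carbonyl carbon and a double-bonded chain carbon, exchanging 2,5-dimethoxyphenyl for 3,4-dimethoxyphenyl gives a 1.3-fold higher number from compound 3 to compound 4 (0.10 log units; within the scatter), so relocating both methoxy groups at once leaves the compounds level in this assay. The 3,4-dimethoxyphenyl group also stands level with the groups carrying one methoxy, with a 1.0-fold higher number from compound 2 to compound 4 (0.02 log units; within the scatter) and a 1.0-fold lower number from compound 1 to compound 4 (0.01 log units; within the scatter). Adding a methoxy group can now be read on two different starting compounds, and it reads the same on both: the same change on two cores in this assay, a 1.2-fold lower number (0.09 log units; within the scatter) from compound 2 to compound 3 and a 1.0-fold lower number (0.01 log units; within the scatter) from compound 1 to compound 4, 1.2-fold (0.07 log units) apart, within the scatter of two such steps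

The aryl groups shown carry only methoxy substituents, so this place has been probed with one kind of group alone. As far as these compounds go, whether a hydroxy group, an amine or a trifluoromethyl group on the aryl group would move the number beyond the scatter remains open.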